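A few compounds are considered here, and "the series" means these few. Any claim that something is new, unique, unknown or untested is made for them only; others in the source may bear on it.

Of the compounds shown here, two have so far been measured in a functional assay on HeLa cells (Homo sapiens) for antiproliferative activity, read by MTT assay, with a stated time of 72 h; a lower number here means a stronger inhibitor, a higher number a weaker inhibitor. Compound 1 `O=c1c(SC(=S)N2CCCC2)coc2ccc(Cl)cc12` gives 16300 nM in this assay, the highest of the two numbers, which makes it the weaker inhibitor of the pair. Compound 2 `O=c1c(CSC(=S)N2CCOCC2)coc2cc(Cl)ccc12` gives 2000 nM in this assay. That gap lies beyond the usual scatter, but the two compounds differ in several places at once, so no single structural change can be tied to it.

Compound 3 `O=c1c(SC(=S)N2CCCC2)coc2ccccc12` has not yet been measured. It differs from compound 1 in one place: hydrogen in place of chloro on an aromatic carbon. A hydrogen atom simply takes the place of the chloro on the aromatic carbon of the core of compound 1, with everything else unchanged.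

Among the measured compounds shown here, no measured pair in this set shows what removing this chloro does, so the step can only be judged from general experience, where small changes of this kind usually shift the number modestly. The step from compound 1 to compound 3 is expected to be a 1.3-fold higher number from compound 1 to compound 3 (0.13 log units; within the scatter), a move toward a weaker inhibitor that may well stay within the scatter. Compound 3 is therefore estimated to give 22000 nM in this assay, with a likely range from 7000 nM to 70000 nM.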

Compound 3, half-maximal inhibitory concentration: 3800 nM
Compound 3: the middle estimate sits 5.8-fold (0.76 log units) above what was measured; measured number below the stated range.
By their numbers in this assay, from the lowest: compounds 2 and 3 (each within the scatter of the next); then compound 1.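

Among the compounds shown here, compound 1 and compound 3 form the first pair here that differs in one place only, so this change can now be read on its own. In this assay, hydrogen in place of chloro on this aromatic carbon, meta to a fused ring and para to a fused ring, gives a 4.3-fold lower number from compound 1 to compound 3 (0.63 log units; beyond the scatter), so within this pair the chloro is not needed for antiproliferative activity and its removal goes with the stronger inhibitor. Why the number falls cannot be told from these compounds, as no measurement here bears on the cause of this step.

This is a single pair on a single carbon of the shared core, so it does not show whether the chloro itself weakens the compound or whether any group at this carbon would do the same, and a fluoro, a methoxy or an amine in that place would help to separate those two readings. For the compounds shown here, it also leaves open whether the same step would appear with a different chain on the other side of the core, such as the one carried by compound 2.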